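Methylphenyl in place of fluorophenyl: estimate for compound 3

A few compounds are considered here, and "the series" means these few. Any claim that something is new, unique, unknown or untested is made for them only; others in the source may bear on it.

Compound 1 `CC(C)c1ccc(-c2nc(SCc3cn(CC(=O)NC(=O)Nc4ccccn4)nn3)nc(Nc3ccc(F)cc3)c2C#N)cc1` is measured in a functional assay on ECa-109 cells (Homo sapiens) for inhibition, read by MTT assay, with a stated time of 72 h (a higher number here means a weaker inhibitor, a lower number a stronger inhibitor), only as a limit; compound 1 gives > 64000 nM there, the limit named in the limit of > 64000 nM in this assay, at which 1 of the 2 values shown sits. Compound 2 `Cc1ccccc1Nc1nc(SCc2cn(CC(=O)NC(=O)Nc3ccccn3)nn2)nc(-c2ccc(C(C)C)cc2)c1C#N` gives 7230 nM in this assay, so an at least 8.8-fold lower number from compound 1 to compound 2 (0.94 log units; beyond the scatter). Compound 3 `Cc1cccc(Nc2nc(SCc3cn(CC(=O)NC(=O)Nc4ccccn4)nn3)nc(-c3ccc(C(C)C)cc3)c2C#N)c1` differs from compound 1 by 3-methylphenyl in place of 4-fluorophenyl on a nitrogen on an aromatic ring. Within the data shown here, the single step that bears on this is the one from compound 1 to compound 2, the same exchange of a methylphenyl for the fluorophenyl, so a lower number is expected in this assay, of comparable or somewhat smaller size. Compound 3 is therefore estimated at 15000 nM (range 4000 nM to 64000 nM), which means an at least 4.2-fold lower number from compound 1 to compound 3 (0.63 log units; beyond the scatter).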

Compound 3, half-maximal inhibitory concentration: 7320 nM
Compound 3: the middle estimate sits 2.0-fold (0.31 log units) above what was measured, within the range that was stated.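

In this assay, 3-methylphenyl in place of 4-fluorophenyl on this nitrogen gives an at least 8.7-fold lower number from compound 1 to compound 3 (0.94 log units; beyond the scatter), so the drop seen with 2-methylphenyl recurs with a second methylphenyl. The size of that step is only a bound set by a limit of the assay: the limit of > 64000 nM in this assay, at which 1 of the 3 values shown sits. 3-methylphenyl in place of 2-methylphenyl gives a 1.0-fold higher number from compound 2 to compound 3 (0.01 log units; within the scatter), so these two methylphenyl groups are not separated in this assay.

Going by these compounds, whether the lower numbers follow from the added methyl or from the loss of the fluorine remains open. An unsubstituted phenyl or a methoxyphenyl on this nitrogen would bear on that question.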